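Bromo for methyl on a phenol-bearing ketone scaffold

The source may hold more compounds than are shown below. What is called first, only, known or untested is meant among the compounds shown, and "the series" means these compounds.

Three compounds sharing one ketone-linked pair of rings were tested in a functional assay on HeLa cells (Homo sapiens) for cytotoxicity, read by sulforhodamine B assay, with a stated time of 48 h; on this read-out lower numbers stand for stronger inhibition and higher numbers for weaker inhibition. Compound 1 `C=CCOc1ccc(Br)cc1C(=O)c1cccnc1` gives 96000 nM in this assay, compound 2 `C=CCOc1ccc(C)cc1C(=O)c1cccnc1` gives 94000 nM, and compound 3 `Cc1ccc(O)c(C(=O)c2cccnc2)c1` gives 26000 nM. The core of compound 3 differs from that of compound 2 by hydrogen in place of allyl on an oxygen on an aromatic ring; this change made a step of a 3.6-fold lower number from compound 2 to compound 3 (0.56 log units; beyond the scatter), so compound 3 stands with the lowest number of the three, its steps to compound 1 and compound 2 both beyond the scatter.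

The change from compound 2 to compound 1 is bromo in place of methyl on an aromatic carbon, and it made a step of a 1.0-fold higher number from compound 2 to compound 1 (0.01 log units; within the scatter). Compound 4 `O=C(c1cccnc1)c1cc(Br)ccc1O` has not yet been measured. It differs from compound 3 by bromo in place of methyl on an aromatic carbon. This is the same kind of change as that from compound 2 to compound 1, though the surroundings differ: in the measured pair the place is para to an allyloxy group, while in compound 3 and compound 4 it is para to a hydroxy group.

Given that the earlier step was flat, the step from compound 3 to compound 4 is expected to be about a 1.1-fold higher number from compound 3 to compound 4 (0.03 log units; within the scatter) in this assay, resting on the single measured example of this change. Compound 4 is therefore estimated at 28000 nM in this assay, with a likely range from 12000 nM to 65000 nM.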

Compound 4, half-maximal inhibitory concentration: 29000 nM
Compound 4: the middle estimate sits 1.0-fold (0.02 log units) below what was measured, within the range that was stated.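

In this assay, bromo in place of methyl on an aromatic carbon gave a 1.1-fold higher number from compound 3 to compound 4 (0.05 log units; within the scatter), and this step on the core of compound 3 agrees with the one on the core of compound 2: the same change on two cores in this assay, a 1.0-fold higher number (0.01 log units; within the scatter) from compound 2 to compound 1 and a 1.1-fold higher number (0.05 log units; within the scatter) from compound 3 to compound 4, 1.1-fold (0.04 log units) apart, within the scatter of two such steps. Hydrogen in place of allyl on the oxygen also carried over, giving a 3.3-fold lower number from compound 1 to compound 4 (0.52 log units; beyond the scatter), in agreement with the step seen with methyl in place of bromo: the same change on two cores in this assay, a 3.6-fold lower number (0.56 log units; beyond the scatter) from compound 2 to compound 3 and a 3.3-fold lower number (0.52 log units; beyond the scatter) from compound 1 to compound 4, 1.1-fold (0.04 log units) apart, within the scatter of two such steps. Across these four compounds, each change had a similar effect whichever form the other place took, but this rests on only two examples of each change in a single assay, and it neither explains either step nor shows that the agreement extends to other groups.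

The compounds shown leave open whether another group at the place para to the hydroxy group, such as an amine, a nitrile or a carboxylic acid, would also leave the number within the scatter. They also leave open how a group on the oxygen other than allyl, such as methyl or a longer chain, would compare with hydrogen and allyl.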